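From 4-bromophenoxy to 2-isopropylphenoxy at the assay limit

This account rests on a few compounds, and the source may have more. Where it says the series, first, only, none or still open, it means among the compounds named here.

Compound 3 `COc1cc(OC)c(/C=C/C(=O)/C=C/c2cc3ccccc3nc2Oc2ccc(Br)cc2)c(OC)c1` gives > 10000 nM as a limit in a functional assay on HGC-27 cells (Homo sapiens) for cytotoxicity, read by MTT assay, with a stated time of 48 h (on this read-out lower numbers stand for stronger inhibition and higher numbers for weaker inhibition), and so has no number. Compound 1 `COc1cc(OC)c(/C=C/C(=O)/C=C/c2cc3ccccc3nc2Cl)c(OC)c1` gives > 10000 nM as a limit too. Compound 2 `COc1ccc(/C=C/C(=O)/C=C/c2cc3ccccc3nc2Oc2ccc(Br)cc2)c(OC)c1` gives > 10000 nM as a limit as well. Compound 4 `COc1cc(OC)c(/C=C/C(=O)/C=C/c2cc3ccccc3nc2Oc2ccccc2C(C)C)c(OC)c1` differs from compound 3 by 2-isopropylphenyl in place of 4-bromophenyl on an oxygen on an aromatic ring with 2-isopropylphenyl in place of 4-bromophenyl on an oxygen on an aromatic ring. The measured steps offer no size, since there is a step that the two limits leave unreadable from compound 1 to compound 3 and also a step that the two limits leave unreadable from compound 2 to compound 3 and all that stands is the limit of > 10000 nM in this assay, at which 3 of the 3 values shown sit, in each case. Going by these compounds, no step beyond the scatter can therefore be argued, and the direction stays open. What is expected in this assay is a step that the limit leaves unreadable from compound 3 to compound 4 on that thin basis. Compound 4 is estimated at 12000 nM with an expected range from 3000 nM to 30000 nM. A limit rather than a number is a likely outcome for compound 4.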

Compound 4, half-maximal inhibitory concentration: > 10000 nM
Compound 4 gave a limit, no number; the forecaster's own chance of this, stated with the estimate: 60%; the middle value does not contradict the limit.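

Compound 4, like compound 1 and compound 3, gives only a limit in this assay, so no step among them can be read: the limit of > 10000 nM in this assay, at which 4 of the 4 values shown sit.

The compounds shown leave open whether 2-isopropylphenoxy, 4-bromophenoxy and chloro differ at all in this assay, and in which direction.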